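Trifluoromethylphenyl Analogue of a Fused Imidazo Core

The compounds below may be only part of what the source reports. "The series", "measured", "known", "first", "only" and "open" are said of these compounds alone.

The series shares one core and varies a single aromatic substituent. Compound 1 `c1ccc(-c2cn3ccnc3c(-c3ccc4ncn(C5CCCCC5)c4c3)n2)cc1` carries an unsubstituted phenyl; in a functional assay on MDA-MB-231 cells (Homo sapiens) for inhibition, read by sulforhodamine B assay, with a stated time of 48 h, tested at 10 uM (on this read-out higher numbers stand for more inhibition at the one concentration tested (going by the name of the read-out) and lower numbers for less inhibition), compound 1 gives 41.5%. Compound 2 `Fc1ccc(-c2cn3ccnc3c(-c3ccc4ncn(C5CCCCC5)c4c3)n2)cc1` carries a 4-fluorophenyl, and in this assay compound 2 gives 15.8%. Compound 3 `CC(=O)c1ccc(-c2cn3ccnc3c(-c3ccc4ncn(C5CCCCC5)c4c3)n2)cc1` carries an acetyl on that phenyl, and in this assay compound 3 gives 7.65%.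

Compound 2 stands second highest of the three: the step of a number 25.7 percentage points lower from compound 1 to compound 2 (beyond the scatter) lies beyond the scatter, whereas the step of a number 8.2 percentage points lower from compound 2 to compound 3 (within the scatter) lies within it. The step of a number 33.9 percentage points lower from compound 1 to compound 3 (beyond the scatter) is also beyond the scatter.

Compound 4 `FC(F)(F)c1cccc(-c2cn3ccnc3c(-c3ccc4ncn(C5CCCCC5)c4c3)n2)c1` differs from compound 2 in one place: 3-(trifluoromethyl)phenyl in place of 4-fluorophenyl on an aromatic carbon. The two measured steps that bear on it both show that adding a group to the phenyl of compound 1 lowered inhibition, and that exchanging fluoro for acetyl changed little. Compound 4 is therefore expected to stay close to compound 2, with the expected step of a number 0.8 percentage points lower from compound 2 to compound 4 (within the scatter) within the scatter. The estimate for compound 4 is 15%, expected between 3% and 35%.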

Compound 4, a percentage reported as inhibition, at one concentration (the size of the read-out at that concentration, not a potency): 21.8%
Beside the measured number, compound 4's estimate is 6.8 percentage points below it; the range from low to high includes it.
By their numbers in this assay, from the lowest: compounds 3, 2 and 4 (each within the scatter of the next, the first and the last beyond it); then compound 1.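

In this assay the 3-(trifluoromethyl)phenyl group also gives less inhibition than the unsubstituted phenyl, with a number 19.7 percentage points lower from compound 1 to compound 4 (beyond the scatter), so the loss seen with the 4-fluorophenyl and 4-acetylphenyl groups extends to a third substituted phenyl. Exchanging 4-fluorophenyl gives a number 6 percentage points higher from compound 2 to compound 4 (within the scatter), while exchanging 4-acetylphenyl gives a number 14.2 percentage points higher from compound 3 to compound 4 (beyond the scatter), so the new group can be told apart from the acetyl-bearing phenyl but not from the fluoro-bearing one. Nothing available here accounts for these differences.

The compounds shown leave open whether the group itself or its place on the phenyl sets the result, a question that a 4-(trifluoromethyl)phenyl analogue of compound 4 would address. They also leave open whether any substituent on this phenyl, such as an amine or a carboxylic acid, could keep the inhibition of compound 1.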